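Dimethoxyphenyl analogue of the trimethoxyphenyl amino-chalcone pyrazole

The source may report more compounds than this note shows. Statements on the series, on what has been measured and on what is new or still open speak of the compounds shown alone.

Compound 1 `COc1cc(-c2cc(/C=C/C(=O)c3ccc(N)cc3)[nH]n2)cc(OC)c1OC` carries a trimethoxyphenyl group on the shared core and a 4-aminophenyl group on the carbonyl carbon. Going by the values given here, in a functional assay on T47D cells (Homo sapiens) for inhibition, read by sulforhodamine B assay, with a stated time of 48 h (a higher number here means a weaker inhibitor of growth, a lower number a stronger inhibitor of growth), compound 1 gives 4300 nM, the lowest of the two numbers so far. Among the compounds with values here, compound 2 `COc1cc(-c2cc(/C=C/C(=O)c3ccc(Cl)c(Cl)c3)[nH]n2)cc(OC)c1OC` gives 15700 nM in this assay, and the step of a 3.7-fold higher number from compound 1 to compound 2 (0.56 log units; beyond the scatter), the only measured step, concerns the aryl group on the carbonyl carbon and not the trimethoxyphenyl end of the molecule.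

Compound 3 `COc1ccc(-c2cc(/C=C/C(=O)c3ccc(N)cc3)[nH]n2)cc1OC` differs from compound 1 at that other end: hydrogen in place of methoxy on an aromatic carbon. Within the data shown here, no measured pair varies this position, so nothing here tells how removing one methoxy group moves the number. The expectation is therefore drawn from compound 1 alone, with wide uncertainty: a change that most likely stays near or somewhat above the number of compound 1, rather than below it.

For compound 3 the expected step is a 1.5-fold higher number from compound 1 to compound 3 (0.18 log units; within the scatter) in this assay, and the estimated value is 6500 nM with a range of 2500 nM to 17000 nM.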

Compound 3, concentration for total growth inhibition: 26000 nM
For compound 3 the middle estimate is 4.0-fold (0.60 log units) below the measured one; measured number outside the range, above it.
By their numbers in this assay, from the lowest: compound 1; then compounds 2 and 3 (each within the scatter of the next).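

Hydrogen in place of methoxy on this aromatic carbon, ortho to a methoxy group and meta to a large group, gives a 6.0-fold higher number from compound 1 to compound 3 (0.78 log units; beyond the scatter) in this assay, so the end of the molecule that the earlier pair left unvaried does move the number. With the 4-aminophenyl group on the carbonyl carbon held constant, this single methoxy group accounts for a step beyond the scatter, and compound 1 stays the lowest of the three, as a 3.7-fold higher number from compound 1 to compound 2 (0.56 log units; beyond the scatter) and the step above both run upward from it. No measurement available here explains why this methoxy group matters.

From the compounds shown here alone, whether another group at this place, such as a hydroxyl, a fluorine or an ethoxy group, would keep the number near that of compound 1 remains open. Going by these compounds alone, also open is whether removing this methoxy group costs the same with the 3,4-dichlorophenyl group of compound 2 on the carbonyl carbon, as the only pair varying this position carries the 4-aminophenyl group.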